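Double-bond geometry: the step from compound 1 to compound 3

The source may hold more compounds than are shown below. What is called first, only, known or untested is meant among the compounds shown, and "the series" means these compounds.

Within the data shown here, in a functional assay on MCF7 cells (Homo sapiens) for cytotoxicity (a lower number here means that less compound is needed, a higher number that more compound is needed for the effect), compound 1 (`CCOC(=O)/C=C/C(=O)/C=C/COC(=O)c1ccccc1`) gives 25.6 ug/mL as the higher of the two numbers so far, while compound 2 (`COC(=O)/C=C/C(=O)CC(O)COC(=O)c1ccccc1`) gives 1.92 ug/mL and lies beyond the scatter from it. Compound 3 (`CCOC(=O)/C=C\C(=O)/C=C/COC(=O)c1ccccc1`) comes next: the two compounds have the same atoms and bonds and differ only in configuration as drawn: 1 of 2 stereo elements differ; a double bond is drawn E in compound 1 and Z in compound 3 and nothing else changes. Among the measured compounds shown here, no measured pair isolates a double-bond configuration, so only a modest shift towards a lower number is expected, possibly none beyond the scatter. The expected move is a 1.6-fold lower number from compound 1 to compound 3 (0.20 log units; within the scatter) and remains an estimate. For compound 3 the estimated value is 16 ug/mL within an expected range of 5 ug/mL to 50 ug/mL in this measurement.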

Compound 3, concentration for half-maximal effect: 4.26 ug/mL
Compound 3: middle estimate off by 3.8-fold (0.57 log units), on the high side; measured number outside the range, below it.
By their numbers in this assay, from the lowest: compound 2; then compound 3; then compound 1.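

In this assay, the change of one double bond from E to Z gives a 6.0-fold lower number from compound 1 to compound 3 (0.78 log units; beyond the scatter). Among these compounds, this is the only measured pair that isolates a double-bond configuration, and it shows that this geometry alone can shift the number beyond the scatter. The step can be assigned to configuration because the structures share all atoms and bonds: the fact that compounds 1 and 3 differ only in the configuration as drawn

The data give no explanation for the lower number of the Z form. The effect of changing the other double bond has not been measured. Also open, from the compounds shown here alone, is whether the same step would appear with a carboxylic acid or an amine on the core of compound 3.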